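The source may report more compounds than this note shows. Statements on the series, on what has been measured and on what is new or still open speak of the compounds shown alone.

Measured so far in a functional assay on PANC-1 cells (Homo sapiens) for antiproliferative activity, read by MTT assay, with a stated time of 48 h; on this read-out lower numbers stand for stronger inhibition and higher numbers for weaker inhibition
- compound 1 `COc1ccc(-c2c(Nc3ccc(C)c(O)c3)c3ccccc3oc2=O)cc1` gives 9750 nM
- compound 2 `COc1ccc(-c2c(Nc3cc(OC)c(OC)c(OC)c3)c3ccc(OC)cc3oc2=O)cc1` gives "not determined" (no result reported)
- compound 3 `COc1ccc(Nc2c(C(=O)C(F)(F)F)c(=O)oc3ccc(OC)cc23)cc1` gives "not determined" (no result reported)

Only compound 1 carries a number in this assay. Compound 3 has no single value to stand on ("not determined" (no result reported)), and compound 2 shares that position ("not determined" (no result reported)). For the measured compounds named here, the series therefore offers no measured step and no ranking.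

The next entry is compound 4 `COc1ccc2oc(=O)c(C(=O)C(F)(F)F)c(Nc3ccc(C)c(O)c3)c2c1`, which has not yet been measured. The change is 3-hydroxy-4-methylphenyl in place of 4-methoxyphenyl on a nitrogen on an aromatic ring, so (4-methoxyphenyl)amino becomes (3-hydroxy-4-methylphenyl)amino while the rest of compound 3 stays in place. Compound 1 carries the same 3-hydroxy-4-methylphenyl on nitrogen, although the rest of its structure differs from that of compound 4.

With no number for compound 3, neither the size nor the direction of this step can be read from the data. Going by the values given here, the only available anchor is compound 1 (9750 nM), so a reading in the same region is expected, with no shift beyond the scatter assumed. That anchor is a single value from a compound that differs elsewhere, so the expected range is kept wide. For compound 4 the estimated value is 7000 nM, with an expected range of 1500 nM to 30000 nM.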

Compound 4, half-maximal inhibitory concentration: 5620 nM
For compound 4 the middle estimate is 1.2-fold (0.10 log units) above the measured one; the range from low to high includes it.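

In this assay, for the compounds shown here, compound 4 gives 5620 nM but compound 3 has no single value, so no step between compound 3 and compound 4 can be read. The compounds shown leave open how the change from (4-methoxyphenyl)amino to (3-hydroxy-4-methylphenyl)amino bears on antiproliferative activity. No measured evidence bears on this result.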